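Hydroxypiperidine in place of the anilino group on the core

The source may report more compounds than this note shows. Statements on the series, on what has been measured and on what is new or still open speak of the compounds shown alone.

Measured so far:
- compound 1 `Cc1ccc(Cl)cc1Nc1nc(C(F)(F)F)ccc1CNC(=O)C(C)c1ccc(NS(C)(=O)=O)c(F)c1`: 14 nM
- compound 2 `CC(C(=O)NCc1ccc(C(F)(F)F)nc1N1CCC(Cc2cc(F)cc(F)c2)CC1)c1ccc(NS(C)(=O)=O)c(F)c1`: 0.4 nM

In a functional assay on CHO-K1 cells for antagonist activity at transient receptor potential cation channel subfamily V member 1 (Homo sapiens), read by FLIPR (on this read-out higher numbers stand for weaker inhibition and lower numbers for stronger inhibition), compound 1 gives 14 nM, the highest of the two numbers; compound 2 gives 0.4 nM, well beyond the scatter from it. Compound 3 `CC(C(=O)NCc1ccc(C(F)(F)F)nc1N1CCC(O)CC1)c1ccc(NS(C)(=O)=O)c(F)c1` differs from compound 1 in one place: 4-hydroxypiperidin-1-yl in place of (5-chloro-2-methylphenyl)amino on an aromatic carbon. For the measured compounds named here, no measured pair shows this change, so its effect is open. The author expects a step upward from compound 1 to compound 3 of an 11-fold higher number from compound 1 to compound 3 (1.03 log units; beyond the scatter), beyond the scatter. For compound 3 the estimate in this assay is 150 nM, within 30 nM to 800 nM.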

Compound 3, inhibition constant: "not active" (no number reported)
Compound 3: no number reported, so the estimate cannot be set against anything.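

For the compounds shown here, compound 3 is reported as "not active" without a number in this assay, so no step from compound 1 to compound 3 can be read. Going by these compounds, the size of the effect of placing 4-hydroxypiperidin-1-yl for (5-chloro-2-methylphenyl)amino stays open. No evidence shown here bears on this result.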